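The source may report more compounds than this note shows. Statements on the series, on what has been measured and on what is new or still open speak of the compounds shown alone.

Among the measured compounds shown here, in an ADME assay on MT4 cells (Homo sapiens) for cytotoxicity (a higher number here means that more compound is tolerated, a lower number that less compound is tolerated), compound 3 `Cc1cc(C)cc(Cn2c(SCC(=O)Nc3ccc(C)cc3Cl)nc3ccccc32)c1` gives 49200 nM, the only true number among the three values available. Compound 1 `Cc1cc(C)cc(S(=O)(=O)n2c(SCC(=O)Nc3ccccc3Br)nc3ccccc32)c1` reads >= 235000 nM, which is a limit of the assay and not a number. Compound 2 `Cc1cc(C)cc(S(=O)(=O)n2c(SCC(=O)Nc3ccccc3[N+](=O)[O-])nc3ccccc32)c1` reads >= 26000 nM, which is also a limit. For the measured compounds named here, the single measured step is a step that the two limits leave unreadable from compound 1 to compound 2, so it offers no size to build on.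

Compound 4 `Cc1cc(C)cc(S(=O)(=O)n2c(SCC(=O)Nc3ccc(C)cc3Cl)nc3ccccc32)c1` differs from compound 3 in one place: (3,5-dimethylphenyl)sulfonyl in place of 3,5-dimethylbenzyl on an aromatic nitrogen. In words, (3,5-dimethylphenyl)sulfonyl stands in place of 3,5-dimethylbenzyl on an aromatic nitrogen. Going by the values given here, compound 1 and compound 2 carry the same (3,5-dimethylphenyl)sulfonyl group, but they differ from compound 4 elsewhere, and no measured pair shows this exchange on its own.

Compound 3 at 49200 nM is therefore the anchor, and no clear shift in this assay can be predicted from it. The expected size is a 1.2-fold higher number from compound 3 to compound 4 (0.09 log units; within the scatter), with no change beyond the usual scatter anticipated. For compound 4 the estimate is 60000 nM, with an expected range from 15000 nM to 240000 nM.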

Compound 4, half-maximal cytotoxic concentration: 5400 nM
Beside the measured number, compound 4's estimate is 11-fold (1.05 log units) above it; measured number below the stated range.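

The exchange at the aromatic nitrogen now has a size: with the rest of the molecule unchanged, (3,5-dimethylphenyl)sulfonyl in place of 3,5-dimethylbenzyl gives a 9.1-fold lower number from compound 3 to compound 4 (0.96 log units; beyond the scatter) in this assay. With the (3,5-dimethylphenyl)sulfonyl group kept, the group on the amide-type nitrogen also matters, since 2-chloro-4-methylphenyl gives an at least 4.8-fold lower number from compound 2 to compound 4 (0.68 log units; beyond the scatter) in place of 2-nitrophenyl and an at least 43-fold lower number from compound 1 to compound 4 (1.63 log units; beyond the scatter) in place of 2-bromophenyl. Compound 1 gives only a limit of the assay and not a number, so the full size of its step stays unknown: the limit of >= 235000 nM in this assay, at which 1 of the 4 values shown sits.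

Going by these compounds, compound 2 also gives only a limit of the assay, which leaves the full size of its step open too: the limit of >= 26000 nM in this assay, at which 1 of the 4 values shown sits. It also remains open whether other groups on the aromatic nitrogen, such as a simple amine-bearing chain or a chain ending in a carboxylic acid, would sit nearer compound 3 or compound 4.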